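Swapping a Furanylmethyl Group for a Thiophenyl Ethyl Group

The source may report more compounds than this note shows. Statements on the series, on what has been measured and on what is new or still open speak of the compounds shown alone.

Of the compounds shown here, two with a shared core have been measured in a functional assay on Right cardiac atrium for agonist activity at histamine H2 receptor (Cavia porcellus), with a stated time of 30 min, in the presence of a further agent that is not named here; a higher number here means that more compound is needed for the effect, a lower number that less compound is needed. Compound 1 `Cc1nc(N)sc1CCCN/C(N)=N/C(=O)NC(c1ccccc1)C(C)C` gives 34.7 nM in this assay. Compound 2 `Cc1nc(N)sc1CCCN/C(N)=N/C(=O)NCc1ccco1` gives 11.8 nM, the lowest of the two numbers; compound 1 sits at a higher number, a gap beyond the usual scatter, so of these two compound 2 needs less compound for the effect.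

Compound 3 `Cc1nc(N)sc1CCCN/C(N)=N/C(=O)NC(C)c1cccs1` has not been measured in this assay. It differs from compound 2 in one place: 1-(thiophen-2-yl)ethyl in place of (furan-2-yl)methyl on an amide-type nitrogen. The amide-type nitrogen keeps its carbonyl neighbour, and the new group carries one more heavy atom than the one it replaces.

Going by the values given here, no step between two measured compounds isolates this change, so the expectation rests on the two values alone. Compound 1, which also carries a branched carbon on that nitrogen, gives 34.7 nM, while compound 2 gives 11.8 nM. Compound 3 is therefore expected to sit somewhat higher than compound 2, with a step of a 1.9-fold higher number from compound 2 to compound 3 (0.27 log units; within the scatter) that may or may not exceed the scatter. The estimate for compound 3 is 22 nM, within a range from 8 nM to 60 nM.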

Compound 3, half-maximal effective concentration: 10 nM
Compound 3: the middle estimate sits 2.2-fold (0.34 log units) above what was measured, within the range that was stated.
By their numbers in this assay, from the lowest: compounds 3 and 2 (each within the scatter of the next); then compound 1.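

On the amide-type nitrogen, 1-(thiophen-2-yl)ethyl in place of (furan-2-yl)methyl gives, in this assay, a 1.2-fold lower number from compound 2 to compound 3 (0.07 log units; within the scatter), so at this position the change in ring hetero atom, the added heavy atom and the branched carbon together leave the number within the scatter. The earlier pair left it possible that a branched carbon on this nitrogen goes with a higher number, but compound 3 carries such a carbon and gives 10 nM, while compound 1, which also carries one, gives 34.7 nM and stands apart from the other two, so branching alone does not account for the number of compound 1. No measurement shown here bears on why the numbers fall as they do.

The change combines two differences, and the compounds shown do not separate the swap from furan to thiophene from the added methyl on the carbon attached to the nitrogen. Also open, from the compounds shown here alone, is how the number would respond to a longer chain between the ring and the amide-type nitrogen, or to an amine or a carboxylic acid on the thiophene ring.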